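Chain-end methyl addition on a diaryl urea series

The compounds below may be only part of what the source reports. "The series", "measured", "known", "first", "only" and "open" are said of these compounds alone.

Compound 1, `CCCCCCCCCCCCc1ccc(NC(=O)Nc2c(C(C)C)cccc2C(C)C)cc1`, gives 15 nM in an assay on isolated protein for inhibition of acyl-CoA:cholesterol acyltransferase (Oryctolagus cuniculus); a higher number here means a weaker inhibitor, a lower number a stronger inhibitor.
Compound 2, `Cc1ccc(NC(=O)Nc2c(C(C)C)cccc2C(C)C)cc1`, gives 250 nM in this assay.
Compound 3, `CCCCCCCCCCc1ccc(NC(=O)Nc2c(C(C)C)cccc2C(C)C)cc1`, gives 13 nM in this assay.

Compound 3 has the lowest number of the three in this assay; compound 1 sits within the scatter of it, and compound 2 lies far above it, as a 19-fold lower number from compound 2 to compound 3 (1.28 log units; beyond the scatter) shows. Compound 4, `CCCCCCCCCCCc1ccc(NC(=O)Nc2c(C(C)C)cccc2C(C)C)cc1`, is not yet measured. It differs from compound 3 by methyl in place of hydrogen on a saturated chain carbon, ten or more bonds along the chain from an aromatic carbon.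

Among the compounds with values here, two measured steps bear on this change. The large ones, a 17-fold higher number from compound 1 to compound 2 (1.22 log units; beyond the scatter) and a 19-fold lower number from compound 2 to compound 3 (1.28 log units; beyond the scatter), concern the whole long chain against hydrogen, not a single added carbon. The closer comparison is a 1.2-fold lower number from compound 1 to compound 3 (0.06 log units; within the scatter), where two carbons were removed from the chain end and the number did not move beyond the scatter. A single methyl at the same place is expected to do even less.

Compound 4 is therefore expected to stay within the scatter of compound 3, with a step of about a 1.1-fold higher number from compound 3 to compound 4 (0.03 log units; within the scatter) in this assay. The estimate for compound 4 is 14 nM, within a range of 7 nM to 28 nM.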

Compound 4, half-maximal inhibitory concentration: 9 nM
Compound 4: middle estimate off by 1.6-fold (0.19 log units), on the high side, and the stated range covers the measured number.
By their numbers in this assay, from the lowest: compounds 4, 3 and 1 (each within the scatter of the next); then compound 2.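

The added methyl gives a 1.4-fold lower number from compound 3 to compound 4 (0.16 log units; within the scatter) in this assay and so shows directly that this single-carbon change stays within the scatter. With a 1.7-fold lower number from compound 1 to compound 4 (0.22 log units; within the scatter) also within the scatter, compounds 1, 3 and 4 now form a flat stretch of three chain lengths that cannot be told apart, while a 28-fold lower number from compound 2 to compound 4 (1.44 log units; beyond the scatter) confirms that the large step lies only between these long chains and the methyl of compound 2. No supporting data explain why the chain end tolerates this change.

Where the number begins to change between methyl and these long chains remains open, and a hexyl chain would bear on that. Also open, going by these compounds, is whether a longer chain, or a carboxylic acid or an amine at the chain end, would leave the number unchanged.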